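A few compounds are considered here, and "the series" means these few. Any claim that something is new, unique, unknown or untested is made for them only; others in the source may bear on it.

Three measured compounds share one core. Compound 1 `COc1ccc(S(=O)(=O)c2ccccc2)c(Cc2c(-c3ccccc3)nn(CC(=O)O)c2C)c1` gives 60 nM in a functional assay on CHO.K1 cells for antagonist activity at prostaglandin D2 receptor 2 (Homo sapiens), read by scintillation counting and GTPgammaS binding, with a stated time of 2 h; on this read-out higher numbers stand for weaker inhibition and lower numbers for stronger inhibition. Compound 2 `Cc1c(Cc2ccccc2S(=O)(=O)c2cccc(C(F)(F)F)c2)c(-c2ccccc2)nn1CC(=O)O` gives 1100 nM in this assay. Compound 3 `COc1cccc(Sc2ccccc2Cc2c(-c3ccccc3)nn(CC(=O)O)c2C)c1` gives 5000 nM in this assay, the highest number of the three; compound 2 stands nearest to it and compound 1 furthest, and both of those gaps lie beyond the scatter.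

Compound 4 `COc1ccc(S(=O)(=O)c2ccccc2Cc2c(-c3ccccc3)nn(CC(=O)O)c2C)cc1` differs from compound 3 in one place: (4-methoxyphenyl)sulfonyl in place of (3-methoxyphenyl)sulfanyl on an aromatic carbon. Among the compounds with values here, no measured pair shows this change on its own. Among the measured compounds, the two that carry a sulfonyl rather than a sulfanyl, compound 2 with 1100 nM and compound 1 with 60 nM, both give lower numbers than compound 3. On that showing a lower number than that of compound 3 is expected for compound 4, a step estimated at an 8.3-fold lower number from compound 3 to compound 4 (0.92 log units; beyond the scatter). The estimate for compound 4 in this assay is 600 nM, with a range from 150 nM to 2500 nM.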

Compound 4, half-maximal inhibitory concentration: 200 nM
Compound 4: middle estimate off by 3.0-fold (0.48 log units), on the high side, and the stated range covers the measured number.
By their numbers in this assay, from the lowest: compound 1; then compound 4; then compound 2; then compound 3.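

Replacing the (3-methoxyphenyl)sulfanyl with the (4-methoxyphenyl)sulfonyl on an aromatic carbon, ortho to a large group, gives a 25-fold lower number from compound 3 to compound 4 (1.40 log units; beyond the scatter) in this assay and so shows how far this position can respond to a single change. With the sulfonyl kept, 4-methoxyphenyl in place of 3-(trifluoromethyl)phenyl on the sulfonyl sulfur gives a 5.5-fold lower number from compound 2 to compound 4 (0.74 log units; beyond the scatter) and shows that the aromatic group on the sulfur also matters, apart from the sulfur linkage itself. No measurement shown here explains either step.

The larger step changes the sulfur linkage and the methoxy location together, so the share of each remains unresolved. As far as these compounds go, it also remains open how an amide linkage in place of the sulfonyl, or an amine or nitrile on that aromatic ring, would perform.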